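This account rests on a few compounds, and the source may have more. Where it says the series, first, only, none or still open, it means among the compounds named here.

For the measured compounds named here, compound 1 `CCC(COC)n1c(=O)c(C)nc2c(-c3cc(F)c(OC)cc3Cl)ccnc21` holds the lowest number of the three compounds measured so far. In a functional assay for antagonist activity at corticotropin-releasing factor receptor 1 (Rattus norvegicus) (on this read-out higher numbers stand for weaker inhibition and lower numbers for stronger inhibition), compound 1 gives 2.1 nM. Compound 2 `CC[C@H](COC)n1c(=O)c(C)nc2c(-c3ccc(Cl)cc3Cl)nccc21` gives 150 nM in this assay, a gap beyond the scatter, and compound 3 `CCC(C1CC1)n1c(=O)c(C)nc2c(-c3cc(C)c(C)c(C)c3C)ccnc21` gives 340 nM in this assay, the number furthest from compound 1. Compound 4 `CC[C@H](C1CC1)n1c(=O)c(C)nc2c(-c3cc(F)c(OC)cc3Cl)ccnc21` has not yet been measured in this assay. It differs from compound 1 in one place: 1-cyclopropylpropyl in place of 1-(methoxymethyl)propyl on an aromatic nitrogen. Going by the values given here, no measured pair shows this change on its own. Compound 3 carries the entering 1-cyclopropylpropyl group, but it differs from compound 4 elsewhere as well, so the value of compound 3, 340 nM, cannot be set against compound 1 to isolate the change. The two groups hold the same number of heavy atoms, and the group that leaves takes the only hydrogen-bond acceptor with it. The step in this assay is expected to be a 1.7-fold higher number from compound 1 to compound 4 (0.22 log units; within the scatter), a slight weakening at most, within the scatter. Compound 4 is therefore estimated at 3.5 nM in this assay, with a range from 1 nM to 14 nM.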

Compound 4, half-maximal inhibitory concentration: 1.7 nM
Compound 4: the middle estimate sits 2.1-fold (0.31 log units) above what was measured; the range from low to high includes it.
By their numbers in this assay, from the lowest: compounds 4 and 1 (each within the scatter of the next); then compound 2; then compound 3.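

For the compounds shown here, the pair of compound 1 and compound 4 is the first to isolate a change on this aromatic nitrogen, and in this assay it gives a 1.2-fold lower number from compound 1 to compound 4 (0.09 log units; within the scatter), so on the core of compound 1 the two groups cannot be told apart by this read-out. The entering 1-cyclopropylpropyl group has the same count of heavy atoms as 1-(methoxymethyl)propyl but no hydrogen-bond acceptor, and it carries a three-membered ring, so on this core a low number at this position does not depend on keeping the acceptor of the leaving group. No evidence on why the two groups match is available here.

From the compounds shown here alone, whether the same match would hold on a different core, such as that of compound 2, stays open, as this single pair speaks only for the core of compound 1. Also open, going by these compounds, are the mirror-image form of the 1-cyclopropylpropyl group and other groups on this nitrogen, such as a 1-(hydroxymethyl)propyl group with a free hydroxyl, a longer chain like 1-ethylbutyl, or an amine-bearing chain.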